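Chloro in place of hydrogen: expecting compound 3

The source may report more compounds than this note shows. Statements on the series, on what has been measured and on what is new or still open speak of the compounds shown alone.

In a functional assay on PC-3 cells (Homo sapiens) for antiproliferative activity, read by sulforhodamine B assay, with a stated time of 48 h (on this read-out lower numbers stand for stronger inhibition and higher numbers for weaker inhibition), compound 1 `CO/N=C1/C(=O)N(CCCCCCC(=O)NO)c2ccccc21` gives 1670 nM and compound 2 `CO/N=C1/C(=O)N(CCCCCCC(=O)NO)c2ccc(Cl)cc21` gives 2330 nM, two values within the scatter of each other. Neither can yet be placed ahead of the other. Compound 3 `CO/N=C1/C(=O)N(CCCCCCC(=O)NO)c2c(Cl)cccc21` has not been measured. It differs from compound 1 by chloro in place of hydrogen on an aromatic carbon, with chloro in place of hydrogen on an aromatic carbon, ortho to a fused ring and meta to a fused ring. For the measured compounds named here, only one measured step is of the same kind, and it is a 1.4-fold higher number from compound 1 to compound 2 (0.14 log units; within the scatter). That chloro sits on a different aromatic carbon, so this step is only a rough guide. A similarly small change in this assay is therefore expected, tilted towards a higher number. The expected step is a 1.5-fold higher number from compound 1 to compound 3 (0.18 log units; within the scatter). For compound 3 the estimated value is 2500 nM, with an expected range from 1000 nM to 6000 nM.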

Compound 3, half-maximal inhibitory concentration: 290 nM
Compound 3: middle estimate off by 8.6-fold (0.94 log units), on the high side; the measured number lies below the stated range.
By their numbers in this assay, from the lowest: compound 3; then compounds 1 and 2 (each within the scatter of the next).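

In this assay, chloro in place of hydrogen on the aromatic carbon ortho to a fused ring and meta to a fused ring gives a 5.8-fold lower number from compound 1 to compound 3 (0.76 log units; beyond the scatter) and so moves the number beyond the scatter, which the earlier chloro step did not do. That earlier step, with the chloro on a different aromatic carbon, was a 1.4-fold higher number from compound 1 to compound 2 (0.14 log units; within the scatter) and stayed within the scatter, so across these two steps the outcome depends on where the chloro sits and not merely on its presence. Nothing at hand explains why this position differs from the other.

On these data alone, whether a fluoro, a methyl or an amine on this same aromatic carbon would give a similar step remains open. So does whether the lower number from this chloro would persist with a shorter or longer chain on the shared core.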